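A second chloro on the shared core

The source may hold more compounds than are shown below. What is called first, only, known or untested is meant among the compounds shown, and "the series" means these compounds.

Measured compounds:
compound 1 `ClCc1cccc(Cn2cnc3ncnc(Cl)c32)c1` – 1230 nM
compound 2 `ClCc1cccc(Cn2cnc3c(Cl)ncnc32)c1` – 1900 nM

In a functional assay on NCI-H23 cells (Homo sapiens) for cytotoxicity, read by sulforhodamine B assay, with a stated time of 48 h (on this read-out lower numbers stand for stronger inhibition of growth and higher numbers for weaker inhibition of growth), compound 1 gives 1230 nM, the lowest of the two numbers shown. Its nearest neighbour, compound 2, gives 1900 nM; the two values lie within the scatter of each other, so nothing can be said about an order between them.

Compound 3 `ClCc1cccc(Cn2cnc3nc(Cl)nc(Cl)c32)c1` has not yet been measured. It differs from compound 1 by chloro in place of hydrogen on an aromatic carbon. Going by the values given here, no step between measured compounds of this kind is available, so the effect of the added chloro rests on expectation alone. The value of compound 1 in this assay is the only anchor, and a step from compound 1 to compound 3 of a 1.2-fold lower number from compound 1 to compound 3 (0.09 log units; within the scatter) is expected, that is a change that may not exceed the scatter. Compound 3 is therefore estimated at 1000 nM, with a range from 350 nM to 3000 nM.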

Compound 3, concentration for 50% growth inhibition: 1540 nM
Beside the measured number, compound 3's estimate is 1.5-fold (0.19 log units) below it; measured number inside the range.
By their numbers in this assay, from the lowest: compounds 1, 3 and 2 (each within the scatter of the next).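

In this assay, chloro in place of hydrogen on an aromatic carbon between two ring nitrogen atoms gives a 1.3-fold higher number from compound 1 to compound 3 (0.10 log units; within the scatter) and so the two compounds cannot be told apart. Going by these compounds alone, the earlier compounds both carry hydrogen on this carbon, so this is the first reading of any other group there, and it shows that a second chloro on the shared core is tolerated in this cell assay, though on a single step. Nothing measured here bears on why the numbers lie so close.

The compounds shown leave open whether an amine, a methoxy group or a longer chain on this same carbon would stand apart from compound 1 by more than the scatter. They also leave open whether the same chloro on compound 2 would do so.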